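Adding cyclopropylcarbonyl to the amine of compound 2

A few compounds are considered here, and "the series" means these few. Any claim that something is new, unique, unknown or untested is made for them only; others in the source may bear on it.

Measured compounds:
- compound 1 `CC(C)(C)OC(=O)N1C[C@@H](n2cc(-c3ccc(N)nc3)nn2)C[C@H]1C(=O)Nc1ccc(Cl)c(C(F)(F)F)c1` gives 4710 nM
- compound 2 `Nc1ccc(-c2cn([C@@H]3CN[C@H](C(=O)Nc4ccc(Cl)c(C(F)(F)F)c4)C3)nn2)cn1` gives 10400 nM
- compound 3 `CC(=O)Nc1ccc(-c2cn([C@@H]3CN[C@H](C(=O)Nc4ccc(Cl)c(C(F)(F)F)c4)C3)nn2)cn1` gives 8980 nM

Compound 2 gives 10400 nM in a functional assay on K562 cells (Homo sapiens) for inhibition, read by MTT assay, with a stated time of 48 h (a lower number here means a stronger inhibitor, a higher number a weaker inhibitor), and cannot be told apart from compound 3, while compound 1 stands apart (a 2.2-fold higher number from compound 1 to compound 2 (0.34 log units; beyond the scatter)). Compound 4 `O=C(Nc1ccc(-c2cn([C@@H]3CN[C@H](C(=O)Nc4ccc(Cl)c(C(F)(F)F)c4)C3)nn2)cn1)C1CC1` changes one thing in compound 2 (cyclopropylcarbonyl in place of hydrogen on a nitrogen on an aromatic ring): cyclopropylcarbonyl in place of hydrogen on a nitrogen on an aromatic ring. The nearest evidence is compound 3, which carries acetyl on that same nitrogen (a 1.2-fold lower number from compound 2 to compound 3 (0.06 log units; within the scatter)). The tert-butoxycarbonyl step of compound 1 concerns an amine nitrogen in a ring, a different place, so it bears little on this change. No step beyond the scatter is therefore expected in this assay, though this rests on a single measured group. The expected step is modest at most (a 1.3-fold lower number from compound 2 to compound 4 (0.11 log units; within the scatter)). Compound 4 is estimated at 8000 nM (range 3500 nM to 18000 nM).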

Compound 4, half-maximal inhibitory concentration: 8770 nM
Compound 4: middle estimate off by 1.1-fold (0.04 log units), on the low side; measured number inside the range.
By their numbers in this assay, from the lowest: compounds 1, 4, 3 and 2 (each within the scatter of the next, the first and the last beyond it).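

In this assay, cyclopropylcarbonyl on this nitrogen on an aromatic ring gives a number that cannot be told apart from the free amino group (a 1.2-fold lower number from compound 2 to compound 4 (0.07 log units; within the scatter)). Replacing methyl with cyclopropyl on the carbonyl carbon also separates nothing (a 1.0-fold lower number from compound 3 to compound 4 (0.01 log units; within the scatter)), so the two acyl groups now tested on this nitrogen read alike and neither stands apart from hydrogen.

On these data alone, whether a benzoyl group, a longer acyl chain or a methanesulfonyl group on the same nitrogen would read differently stays open. Nothing shown explains why these three compounds read alike.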